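The source may report more compounds than this note shows. Statements on the series, on what has been measured and on what is new or still open speak of the compounds shown alone.

For the measured compounds named here, compound 1 `CN(C)c1ccc(Nc2nccc(-c3ccccn3)n2)cc1` is one of two compounds measured in a functional assay for inhibition, with Homo sapiens as the target; a higher number here means a weaker inhibitor, a lower number a stronger inhibitor; in it compound 1 gives 3300 nM, the highest of the two numbers. Compound 2 `CC(=O)N(C)c1ccc(Nc2nccc(-c3ccccn3)n2)cc1` gives 1800 nM, and the step of a 1.8-fold lower number from compound 1 to compound 2 (0.26 log units; within the scatter) comes from acetyl in place of methyl on a nitrogen on an aromatic ring. Compound 3 `CN(C)c1ccc(Nc2nccc(-c3ccncc3)n2)cc1` differs from compound 1 elsewhere: pyridin-4-yl in place of pyridin-2-yl on an aromatic carbon. Going by the values given here, no measured step touches this change, so the step is expected to stay within the scatter, with wide uncertainty: a 1.5-fold higher number from compound 1 to compound 3 (0.18 log units; within the scatter). For compound 3 in this assay the estimated value is 5000 nM, between 1500 nM and 20000 nM.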

Compound 3, half-maximal inhibitory concentration: 3700 nM
Compound 3: the middle estimate sits 1.4-fold (0.13 log units) above what was measured, within the range that was stated.
By their numbers in this assay, from the lowest: compounds 2, 1 and 3 (each within the scatter of the next, the first and the last beyond it).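

For the compounds shown here, this is the first measured change at this position on the shared core. In this assay, pyridin-4-yl in place of pyridin-2-yl gives a 1.1-fold higher number from compound 1 to compound 3 (0.05 log units; within the scatter), so for this pair, changing where the ring nitrogen sits produces no difference that the assay can resolve. No outside measurement helps to interpret this result.

On these data alone, whether pyridin-3-yl or a plain phenyl ring would also stay within the scatter remains open. So does the outcome of a pyridine carrying an amine or a carboxylic acid at this position.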